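Replacing pyrrolidin-1-yl with 1H-imidazol-1-yl on compound 2

The source may report more compounds than this note shows. Statements on the series, on what has been measured and on what is new or still open speak of the compounds shown alone.

Compound 1 `CC(=O)N(C)CC#CCn1ccnc1` - 1.4 mg/kg
Compound 2 `COC(=O)N(C)CC#CCN1CCCC1` - 3 mg/kg

In a functional assay on the whole organism for agonist activity, with Mus musculus as the target (on this read-out lower numbers stand for an effect already at smaller amounts and higher numbers for an effect only at larger amounts of compound), compound 2 has the higher of the two numbers, and the gap to compound 1 lies beyond the scatter. On a saturated chain carbon bound to a triple-bonded carbon, compound 3 `COC(=O)N(C)CC#CCn1ccnc1` differs from compound 2 by 1H-imidazol-1-yl in place of pyrrolidin-1-yl on a saturated chain carbon bound to a triple-bonded carbon and in nothing else. For the measured compounds named here, no measured pair isolates this change. Compound 1 also carries 1H-imidazol-1-yl and gives 1.4 mg/kg in this assay, so no step beyond the scatter is expected, in either direction. The expected change is a 1.2-fold lower number from compound 2 to compound 3 (0.08 log units; within the scatter) in this assay and stays within the scatter. The estimate for compound 3 is 2.5 mg/kg, expected to fall from 0.8 mg/kg to 10 mg/kg on repeat measurement.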

Compound 3, dose for half-maximal effect: 4.5 mg/kg
Estimate against measurement, compound 3: 1.8-fold (0.26 log units) below, and the stated range covers the measured number.
By their numbers in this assay, from the lowest: compound 1; then compounds 2 and 3 (each within the scatter of the next).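

In this assay, 1H-imidazol-1-yl in place of pyrrolidin-1-yl on a saturated chain carbon bound to a triple-bonded carbon gives a 1.5-fold higher number from compound 2 to compound 3 (0.18 log units; within the scatter), so this swap produces no step beyond the scatter when methoxy stays on the carbonyl carbon. For the compounds shown here, with 1H-imidazol-1-yl held constant, methoxy in place of methyl on a carbonyl carbon gives a 3.2-fold higher number from compound 1 to compound 3 (0.51 log units; beyond the scatter), the only one of the two steps beyond the scatter. No measured property bears on either step.

Still open, on these data alone, is how pyrrolidin-1-yl behaves with methyl on the carbonyl carbon. Also open, as far as these compounds go, is how dimethylamino on the chain carbon or ethoxy on the carbonyl carbon would read out.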